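This account rests on a few compounds, and the source may have more. Where it says the series, first, only, none or still open, it means among the compounds named here.

Three compounds have been measured in an assay for inhibition of Amine oxidase [flavin-containing] B (Homo sapiens), read by fluorescence, using microsomes, with a stated time of 30 min; on this read-out lower numbers stand for stronger inhibition and higher numbers for weaker inhibition:

Compound 1, `CN(C)Cc1cc(=O)oc2cc(OCc3ccc(CO)cc3)ccc12`: 630 nM
Compound 2, `CN(C)Cc1cc(=O)oc2cc(OCc3cccc(CO)c3)ccc12`: 1100 nM
Compound 3, `Cc1cc2ccc(OCC3CCN(Cc4ccc(CO)cc4)CC3)cc2oc1=O`: 3100 nM

Compound 3 gives the highest number of the three, beyond the scatter of both others. The difference between its core and that of compound 1 is not broken down here. Compound 2 differs from compound 1 only by 3-(hydroxymethyl)phenyl in place of 4-(hydroxymethyl)phenyl on a saturated chain carbon bound to an oxygen on an aromatic ring, and that step is a 1.7-fold higher number from compound 1 to compound 2 (0.24 log units; within the scatter). Compound 4, `Cc1cc2ccc(OCC3CCN(Cc4cccc(CO)c4)CC3)cc2oc1=O`, has not yet been measured; it differs from compound 3 by 3-(hydroxymethyl)phenyl in place of 4-(hydroxymethyl)phenyl on a saturated chain carbon bound to an amine nitrogen in a ring, the same kind of change as from compound 1 to compound 2, though the place differs: there the carbon is bound to an oxygen on an aromatic ring, here to an amine nitrogen in a ring. Compound 4 is expected to give 4500 nM, between 2000 nM and 10000 nM. From compound 3 to compound 4 the expected step is a 1.5-fold higher number from compound 3 to compound 4 (0.16 log units; within the scatter), because the same kind of change gave a 1.7-fold higher number from compound 1 to compound 2 (0.24 log units; within the scatter).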

Compound 4, half-maximal inhibitory concentration: 1100 nM
The estimate for compound 4 lay 4.1-fold (0.61 log units) above the measured number; measured number outside the range, below it.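

The change from 4-(hydroxymethyl)benzyl to 3-(hydroxymethyl)benzyl, on a saturated chain carbon bound to an amine nitrogen in a ring, gives a 2.8-fold lower number from compound 3 to compound 4 (0.45 log units; beyond the scatter). The same change does not have the same outcome on the two cores: the same change on two cores in this assay, a 1.7-fold higher number (0.24 log units; within the scatter) from compound 1 to compound 2 and a 2.8-fold lower number (0.45 log units; beyond the scatter) from compound 3 to compound 4, 4.9-fold (0.69 log units) apart, beyond the scatter of two such steps. Going by these compounds alone, this shows that the step read on one core did not carry over to the other, but with only one pair per core it does not show which difference between the cores is responsible.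

The compounds shown leave open whether a carboxylic acid or an amine in place of the hydroxymethyl group would also depend on the core in this way. They also leave open whether a longer chain carrying the hydroxyl would do so.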